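Halogen swap on the pendant phenyl of compound 3

The source may report more compounds than this note shows. Statements on the series, on what has been measured and on what is new or still open speak of the compounds shown alone.

Three compounds of this series have been run in an ADME assay on microsomes from liver (Homo sapiens) for metabolic stability, tested at 2.5 uM; on this read-out lower numbers stand for slow clearance and higher numbers for fast clearance. Compound 1 `O=S(=O)(c1cc(F)cc(F)c1)c1cnc2cc(F)ccc2c1-c1ccc(Cl)cc1` gives 0.03 mL/min, compound 2 `N#Cc1cccc(S(=O)(=O)c2cnc3cc(F)ccc3c2-c2cccc(Cl)c2)c1` gives 0.99 mL/min, and compound 3 `O=S(=O)(c1cc(F)cc(F)c1)c1cnc2cc(F)ccc2c1-c1cccc(F)c1` gives 0.06 mL/min. Compound 3 thus stands second highest of the three numbers: it sits nearest compound 1, the step of a 2.0-fold higher number from compound 1 to compound 3 (0.30 log units; within the scatter) being within the scatter, and furthest from compound 2, whose number lies beyond the scatter on the high side.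

Compound 4 `O=S(=O)(c1cc(F)cc(F)c1)c1cnc2cc(F)ccc2c1-c1cccc(Cl)c1` differs from compound 3 in one place: chloro in place of fluoro on an aromatic carbon. Among the measured compounds shown here, the only measured step that bears on a halogen change on this phenyl is a 2.0-fold higher number from compound 1 to compound 3 (0.30 log units; within the scatter), which is within the scatter. Compound 2 also carries a 3-chlorophenyl but differs from compound 4 elsewhere as well, so its value gives no clean guide. No step beyond the scatter is therefore expected in this assay; the expected step is no change at the digits printed from compound 3 to compound 4 (within the scatter). The estimate for compound 4 in this assay is 0.06 mL/min, with a range from 0.02 mL/min to 0.18 mL/min.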

Compound 4, intrinsic clearance in a liver preparation (reported as CLH), per the amount of preparation that the assay uses: 0.22 mL/min
Beside the measured number, compound 4's estimate is 3.7-fold (0.56 log units) below it; measured number above the stated range.
By their numbers in this assay, from the lowest: compounds 1 and 3 (each within the scatter of the next); then compound 4; then compound 2.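

In this assay, the change from 3-fluorophenyl to 3-chlorophenyl gives a 3.7-fold higher number from compound 3 to compound 4 (0.56 log units; beyond the scatter), so the halogen at this place matters, which a 2.0-fold higher number from compound 1 to compound 3 (0.30 log units; within the scatter) did not reveal. Among the compounds shown here, the chlorine's place on the ring also matters: 3-chlorophenyl in place of 4-chlorophenyl gives a 7.3-fold higher number from compound 1 to compound 4 (0.87 log units; beyond the scatter), while with 3-chlorophenyl held constant, 3,5-difluorophenyl in place of 3-cyanophenyl on the sulfonyl sulfur gives a 4.5-fold lower number from compound 2 to compound 4 (0.65 log units; beyond the scatter), the first one-place reading for that group. Nothing available explains any of these steps.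

From the compounds shown here alone, whether the halogen step carries over when 3-cyanophenyl sits on the sulfonyl sulfur remains open. Also open, going by these compounds, is how a methoxy group, a trifluoromethyl group or an amine would read on the pendant phenyl in place of the halogen.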